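The source may hold more compounds than are shown below. What is called first, only, known or untested is meant among the compounds shown, and "the series" means these compounds.

Measured compounds in a functional assay on SH-SY5Y cells (Homo sapiens) for cytotoxicity, read by MTT assay, with a stated time of 48 h; a lower number here means a stronger inhibitor, a higher number a weaker inhibitor:
- compound 1 `[O-][S+](CCC(F)=C(F)F)c1nccs1`: > 120000 nM, which is a limit of the assay and not a number
- compound 2 `[O-][S+](CCC(F)=C(F)F)c1nc2ccccc2[nH]1`: > 120000 nM, which is also a limit and not a number

Going by the values given here, compound 1 therefore stands at the limit of > 120000 nM in this assay, at which 2 of the 2 values shown sit, and no finished number for it is known; the same holds for compound 2, so nothing here separates the two, and no step between measured compounds can be drawn.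

Compound 3 `[O-][S+](CCC(F)=C(F)F)c1ncc(-c2ccncc2)s1` has not yet been measured in this assay. It differs from compound 1 in one place: pyridin-4-yl in place of hydrogen on an aromatic carbon. Among the compounds with values here, no measured pair shows what such a change does here, so the expectation rests only on where compound 1 sits. A step from compound 1 to compound 3 of no more than the usual scatter is expected, in no firm direction.

Compound 3 is estimated to give about 120000 nM in this assay, with a likely range from 30000 nM to 400000 nM, which corresponds to an expected step of a number no higher from compound 1 to compound 3 (the limit leaves the size open).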

Compound 3, half-maximal inhibitory concentration: > 120000 nM
Compound 3 was reported as a limit; the forecaster's own chance of this, stated with the estimate: 65%; the middle value lies on the limit itself.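

Compound 3, like compound 1, is reported only as a limit and not as a number, so the change from hydrogen to pyridin-4-yl cannot be read as a step: the limit of > 120000 nM in this assay, at which 3 of the 3 values shown sit.

The compounds shown leave open how these three compounds would rank in this assay, since none has a finished number.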